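A few compounds are considered here, and "the series" means these few. Any claim that something is new, unique, unknown or untested is made for them only; others in the source may bear on it.

- compound 1 `COc1cccc(Br)c1-c1nc(CN2CCC(C(=O)NCCCN3C[C@H](C)C[C@H](C)C3)CC2)c(C)o1`: 14900 nM
- compound 2 `Cc1cccc(C)c1-c1nc(CN2CCC(C(=O)NCCCN3C[C@H](C)C[C@H](C)C3)CC2)c(C)o1`: 21000 nM

In an ADME assay on Huh7.5.1 cells (Homo sapiens) for cytotoxicity, read by ATP content, with a stated time of 48 h (on this read-out higher numbers stand for lower toxicity in this test and lower numbers for higher toxicity in this test), compound 2 gives 21000 nM. Going by the values given here, its only neighbour so far, compound 1, gives 14900 nM, and the two cannot be told apart within the usual scatter. Compound 3 `Cc1ccc(-c2nc(CN3CCC(C(=O)NCCCN4C[C@H](C)C[C@H](C)C4)CC3)c(C)o2)c(C)c1` keeps the shared core of compound 2 and alters a single group: 2,4-dimethylphenyl in place of 2,6-dimethylphenyl on an aromatic carbon. The two have the same atoms, joined differently. Among the compounds with values here, one measured step bears on this, a swap of the group at the same place, 2,6-dimethylphenyl in place of 2-bromo-6-methoxyphenyl: a 1.4-fold higher number from compound 1 to compound 2 (0.15 log units; within the scatter). Within the data shown here, no measured compound carries 2,4-dimethylphenyl, so this single step is thin evidence. Even so, a larger swap from compound 1 to compound 2 stayed small, so no shift beyond the scatter is expected in this assay. The expected result is a 1.2-fold lower number from compound 2 to compound 3 (0.07 log units; within the scatter). The estimated value for compound 3 is 18000 nM, within an expected range of 9000 nM to 36000 nM.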

Compound 3, half-maximal cytotoxic concentration: 4110 nM
The estimate for compound 3 lay 4.4-fold (0.64 log units) above the measured number, and the stated range ends above it.
By their numbers in this assay, from the lowest: compound 3; then compounds 1 and 2 (each within the scatter of the next).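

In this assay, the result shows that this aromatic carbon is sensitive to how the phenyl group is arranged, and not only to which atoms it carries. With the same atoms joined differently, 2,4-dimethylphenyl in place of 2,6-dimethylphenyl gives a 5.1-fold lower number from compound 2 to compound 3 (0.71 log units; beyond the scatter) and so higher toxicity in this test, a shift beyond the scatter that the earlier swap between compound 1 and compound 2 gave no sign of. The comparison with the bromo and methoxy group points the same way, with a 3.6-fold lower number from compound 1 to compound 3 (0.56 log units; beyond the scatter) beyond the scatter, but no measurement here explains either shift.

As far as these compounds go, it remains open whether other arrangements of the two methyl groups, such as 3,5-dimethylphenyl, would also give a lower number. A plain phenyl, a 4-methylphenyl or a pyridine ring at this place could help show which feature of 2,4-dimethylphenyl goes with the change.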